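The source may hold more compounds than are shown below. What is called first, only, known or untested is meant among the compounds shown, and "the series" means these compounds.

Measured in a functional assay on MGC-803 cells (Homo sapiens) for antiproliferative activity, read by MTT assay, with a stated time of 48 h; a higher number here means a weaker inhibitor, a lower number a stronger inhibitor:
- Compound 1 `CCCCCCCCCn1cc(COC[C@@H]2OC[C@H](N)[C@@H]2O)nn1`: 13800 nM
- Compound 2 `CCCCCCCCCCCCCCCCn1cc(COC[C@@H]2OC[C@H](N)[C@@H]2O)nn1`: 27900 nM
- Compound 3 `CCCCCCCCCn1cc(COC[C@@H]2OC[C@H](N)[C@H]2O)nn1`: > 128000 nM (a limit)

Compound 3 is known only by a limit, not by a number. It is the weakest of the three on the numbers shown, as the step of an at least 9.2-fold higher number from compound 1 to compound 3 (0.96 log units; beyond the scatter) sets it apart, and this step goes with the fact that compounds 1 and 3 differ only in the configuration as drawn. The next compound, compound 4 `CCCCCCCCCCCCCCn1cc(COC[C@@H]2OC[C@H](N)[C@H]2O)nn1`, keeps the configuration of compound 3 and carries a longer chain. The change is pentyl in place of hydrogen on a saturated chain carbon, nine bonds along the chain from an aromatic nitrogen.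

Within the data shown here, two measured steps bear on this. The only chain lengthening measured, a 2.0-fold higher number from compound 1 to compound 2 (0.31 log units; beyond the scatter), was modest and led towards weaker inhibition, but it was seen with the configuration of compound 1, so it transfers only with caution. The configuration step shows that compound 3 lost most of the activity of compound 1, and nothing measured suggests that a longer chain restores it. Little change is therefore expected in this assay, with compound 4 remaining a weak inhibitor, quite possibly reported only as a limit. The expected step is an at least 1.1-fold lower number from compound 3 to compound 4 (0.06 log units; that floor lies within the scatter). For compound 4 the estimate is 110000 nM, with an expected range of 35000 nM to 256000 nM.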

Compound 4, half-maximal inhibitory concentration: 8790 nM
Compound 4: middle estimate off by 13-fold (1.10 log units), on the high side; the whole stated range lies above it.
By their numbers in this assay, from the lowest: compounds 4 and 1 (each within the scatter of the next); then compound 2. At a limit, above all of these: compound 3.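

In this assay, the pentyl change at a saturated chain carbon, nine bonds along the chain from an aromatic nitrogen, gives an at least 14-fold lower number from compound 3 to compound 4 (1.16 log units; beyond the scatter), so with this configuration the chain position is far from silent. The only earlier chain step, heptyl in place of hydrogen at the same place, gave a 2.0-fold higher number from compound 1 to compound 2 (0.31 log units; beyond the scatter) with the configuration of compound 1 and ran the other way, so among these few compounds the direction of a chain lengthening differs between the two configurations, although the two added groups also differ. Among these compounds, for compound 3 the value > 128000 nM is a limit, and the new step shows only that the configuration of compound 3 does not by itself fix weak inhibition.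

The compounds shown leave open how the chain of compound 4 would behave with the configuration of compound 1, and how the longer chain of compound 2 would behave with the configuration of compound 3. They also leave open whether a shorter chain, a still longer chain, or a hydroxyl or phenyl group at the chain end would keep the activity of compound 4.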